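Compound 3 to compound 4: replacing morpholin-4-yl

The source may report more compounds than this note shows. Statements on the series, on what has been measured and on what is new or still open speak of the compounds shown alone.

In a functional assay on HL-60 cells (Homo sapiens) for antiproliferative activity, read by MTT assay, with a stated time of 24 h (on this read-out higher numbers stand for weaker inhibition and lower numbers for stronger inhibition), compound 1 `CCCCc1oc2ccccc2c1C(=O)c1ccc(OCC(=O)Nc2cccc(OC)c2)cc1` reads > 50000 nM as a limit of the assay. Compound 2 `CCCCc1oc2ccccc2c1C(=O)c1ccc(OCC(=O)N[C@@H](C)c2ccccc2)cc1` reads > 50000 nM as a limit too. Going by the values given here, compound 3 `CCCCc1oc2ccccc2c1C(=O)c1ccc(OCCCC(=O)N2CCOCC2)cc1` gives 34100 nM as the only actual number so far. Compound 4 `CCCCc1oc2ccccc2c1C(=O)c1ccc(OCCCC(=O)N[C@H](C)c2ccccc2)cc1` carries (1-phenylethyl)amino in place of morpholin-4-yl on a carbonyl carbon and so keeps the chain of compound 3. Compound 2 also holds (1-phenylethyl)carbamoyl, which makes an at least 1.4-fold lower number from compound 2 to compound 3 (0.16 log units; that floor lies within the scatter) the closer guide, and an at least 1.4-fold lower number from compound 1 to compound 3 (0.16 log units; that floor lies within the scatter) points the same way. Neither floor clears the scatter, so no step beyond the scatter is expected in this assay and a reading at the limit stays possible. The estimated step is a 1.1-fold higher number from compound 3 to compound 4 (0.02 log units; within the scatter) at most modest. For compound 4 the estimate is 36000 nM with an expected range from 12000 nM to 80000 nM in this read-out.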

Compound 4, half-maximal inhibitory concentration: > 50000 nM
Compound 4 gave a limit, no number; the forecaster's own chance of this, stated with the estimate: 40%; middle value at least 1.3-fold (0.14 log units) away from the limit.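

In this assay, (1-phenylethyl)amino in place of morpholin-4-yl on a carbonyl carbon gives an at least 1.4-fold higher number from compound 3 to compound 4 (0.16 log units; that floor lies within the scatter), so this position has now been changed with the chain of compound 3 held constant. Compound 4 reads as a limit, not a number. The true size of this step therefore stays undefined, and morpholin-4-yl remains the only group here with a measured number: the limit of > 50000 nM in this assay, at which 3 of the 4 values shown sit.

Going by these compounds, whether the change has any effect beyond the scatter remains open. Also open, on these data alone, is whether piperazin-1-yl or a carboxylic acid at this carbonyl carbon would give a reading clear of the limit.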